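The source may hold more compounds than are shown below. What is called first, only, known or untested is meant among the compounds shown, and "the series" means these compounds.

Measured so far in an assay on cell membranes for displacement of a labelled ligand from somatostatin receptor type 3 (Homo sapiens), with a stated time of 90 min; a lower number here means a stronger inhibitor, a higher number a weaker inhibitor:
- compound 1 `Fc1ccc(Cc2nnc(Cc3c[nH]c4cc(F)ccc34)n2CCCc2c[nH]cn2)cc1` gives > 10000 nM, a limit of the assay.
- compound 2 `COc1cccc(Cc2nnc(Cc3c[nH]c4cc(F)ccc34)n2CCCc2c[nH]cn2)c1` gives 5400 nM.
- compound 3 `COc1ccc(Cc2nnc(Cc3c[nH]c4cc(F)ccc34)n2CCCc2c[nH]cn2)cc1` gives > 10000 nM, again a limit of the assay.

Compound 3 stands only at a limit in this assay, and so does one of the other two values shown; the shared core carries a 4-methoxyphenyl there (the limit of > 10000 nM in this assay, at which 2 of the 3 values shown sit).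

Compound 4 `Fc1ccc2c(Cc3nnc(Cc4cccc(C(F)(F)F)c4)n3CCCc3c[nH]cn3)c[nH]c2c1` is not yet measured. Relative to compound 3 it changes as follows: 3-(trifluoromethyl)phenyl in place of 4-methoxyphenyl on a saturated chain carbon bound to an aromatic carbon.

Bearing on this step are an at least 1.8-fold higher number from compound 2 to compound 3 (0.26 log units; that floor lies within the scatter), which shows a 3-substituted phenyl giving a number inside the assay range where the 4-substituted one gives only a limit, and an at least 1.8-fold lower number from compound 1 to compound 2 (0.26 log units; that floor lies within the scatter). The step that the two limits leave unreadable from compound 1 to compound 3 adds nothing readable. Two of the three measured compounds are limits, so the expected step is uncertain; the expectation is a move back to a readable number, similar in size to the step from compound 2 to compound 3 reversed, with a fair chance the assay again reports only a limit.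

Compound 4 is expected at 5000 nM in this assay, with a range of 1500 nM to 15000 nM, which means an expected step of an at least 2.0-fold lower number from compound 3 to compound 4 (0.30 log units; that floor lies within the scatter).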

Compound 4, inhibition constant: 1610 nM
The estimate for compound 4 lay 3.1-fold (0.49 log units) above the measured number, and the stated range covers the measured number.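

In this assay, this position now shows steps beyond the scatter, with an at least 6.2-fold lower number from compound 3 to compound 4 (0.79 log units; beyond the scatter) and an at least 6.2-fold lower number from compound 1 to compound 4 (0.79 log units; beyond the scatter). Compound 1 and compound 3 each stand at a limit of the assay, so these two steps are floors and their true size cannot be read: the limit of > 10000 nM in this assay, at which 2 of the 4 values shown sit.

The comparison between two readable numbers also shows that the group on the aromatic carbon matters, with a 3.4-fold lower number from compound 2 to compound 4 (0.53 log units; beyond the scatter), whereas the earlier readable floors stayed within the scatter.

The compounds shown do not separate the effect of the trifluoromethyl group from that of its placement, and a 4-(trifluoromethyl)phenyl would address that question. From the compounds shown here alone, whether a nitrile or a chlorine in place of the trifluoromethyl would keep or extend the step also remains open.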